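A few compounds are considered here, and "the series" means these few. Any claim that something is new, unique, unknown or untested is made for them only; others in the source may bear on it.

Measured so far:
- Compound 1 `COC(=O)C[C@H](NC(=O)OC(C)(C)C)C(=O)N(Cc1ccc(F)cc1)C1(C(=O)NCc2ccccc2)CCNCC1`: 100000 nM
- Compound 2 `COC(=O)C[C@H](NC(=O)OC(C)(C)C)C(=O)N(Cc1ccc(F)cc1)C1(C(=O)NCc2ccccc2)CCN(C2CCCCC2)CC1`: 73000 nM

Compound 1 was tested in an ADME assay on MDCK cells (Canis lupus familiaris) for cytotoxicity, read by microscopy, with a stated time of 72 h (a higher number here means that more compound is tolerated, a lower number that less compound is tolerated), where it gives 100000 nM. Among the two numbers measured it stands highest, with compound 2 nearest: the step of a 1.4-fold lower number from compound 1 to compound 2 (0.14 log units; within the scatter) is the only measured step, and it lies within the scatter, so the two compounds cannot be told apart on this read-out.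

Compound 3 `CC(C)(C)OC(=O)N[C@@H](CC(=O)O)C(=O)N(Cc1ccc(F)cc1)C1(C(=O)NCc2ccccc2)CCNCC1` has not yet been measured in this assay. It differs from compound 1 as follows: hydrogen in place of methyl on an oxygen next to a carbonyl group. Within the data shown here, the one measured step concerns a cyclohexyl entering on an amine nitrogen in a ring, a different place from the oxygen changed here, so it does not speak directly to this change; what it does show is that a change elsewhere in the shared core moved the number no further than the scatter.

On that basis compound 3 is expected to show a step of no change at the digits printed from compound 1 to compound 3 (within the scatter), that is, no change beyond the scatter. The estimate for compound 3 is 100000 nM, within a range of 50000 nM to 200000 nM.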

Compound 3, minimum cytotoxic concentration: 79000 nM
Compound 3: middle estimate off by 1.3-fold (0.10 log units), on the high side, within the range that was stated.
By their numbers in this assay, from the lowest: compounds 2, 3 and 1 (each within the scatter of the next).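

In this assay, putting hydrogen in place of methyl on an oxygen next to a carbonyl group, which turns the methoxycarbonyl into a carboxy group, gives a 1.3-fold lower number from compound 1 to compound 3 (0.10 log units; within the scatter). Among these compounds, the earlier step concerned only the amine nitrogen in a ring, so this is the first reading at this oxygen, and on this read-out compound 1 and compound 3 cannot be told apart. No measurement shown here bears on why this change behaves as it does. 

The compounds shown leave open how the same read-out would respond to other groups in place of the methoxycarbonyl, such as an ethoxycarbonyl or a primary amide. They also leave open whether the carboxy group and a cyclohexyl on the amine nitrogen, present together on the shared core, would still fall within the scatter of compound 1.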